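Replacing the phenyl on the shared core of compound 1

The source may hold more compounds than are shown below. What is called first, only, known or untested is meant among the compounds shown, and "the series" means these compounds.

compound 1: `COc1cc(C(=O)c2sc(-c3ccc(-c4ccccc4)cc3)cc2N)cc(OC)c1OC` — > 10000 nM
compound 2: `COc1cc(C(=O)c2sc(-c3ccc(I)cc3)cc2N)cc(OC)c1OC` — 400 nM
compound 3: `COc1ccc(-c2cc(N)c(C(=O)c3cc(OC)c(OC)c(OC)c3)s2)cc1` — not yet measured

In a functional assay on L1210 cells (Mus musculus) for antiproliferative activity (a higher number here means a weaker inhibitor, a lower number a stronger inhibitor), compound 1 gives only a limit of the assay, > 10000 nM. Compound 2 gives 400 nM. Going by the values given here, the single measured step, an at least 25-fold lower number from compound 1 to compound 2 (1.39 log units; beyond the scatter), is a floor on the true change because compound 1 sits at the limit of > 10000 nM in this assay, at which 1 of the 2 values shown sits. Compound 3 carries methoxy in place of phenyl on an aromatic carbon. Both changes remove the phenyl, so a lowering beyond the scatter is expected for compound 3, though the methoxy need not match the iodo. Compound 3 is expected near 1500 nM (range 300 nM to 8000 nM). The expected step is an at least 6.6-fold lower number from compound 1 to compound 3 (0.82 log units; beyond the scatter).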

Compound 3, half-maximal inhibitory concentration: 45 nM
For compound 3 the middle estimate is 33-fold (1.52 log units) above the measured one, and the stated range ends above it.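

At this position in this assay, the replacement of phenyl by methoxy gives an at least 220-fold lower number from compound 1 to compound 3 (2.34 log units; beyond the scatter), so a large lowering does not depend on iodo. The two replacements are not equivalent: methoxy in place of iodo gives an 8.9-fold lower number from compound 2 to compound 3 (0.95 log units; beyond the scatter). The first of these steps is only a floor, as the value for compound 1 is a limit of the assay: the limit of > 10000 nM in this assay, at which 1 of the 3 values shown sits.

From the compounds shown here alone, whether the gain over iodo belongs to methoxy alone remains open. An ethoxy, a hydroxyl or an amine at the same place would test this.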